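The source may report more compounds than this note shows. Statements on the series, on what has been measured and on what is new or still open speak of the compounds shown alone.

Compound 1 `Cc1ccc(NC2=CC(=O)c3nc4n(c3C2=O)[C@H]2OC[C@@H](O)[C@H]2OC4)cc1C` stands alone among the three measured compounds in giving a number in a functional assay on MCF7 cells (Homo sapiens) for inhibition, read by sulforhodamine B assay (on this read-out higher numbers stand for weaker inhibition and lower numbers for stronger inhibition), namely 2080 nM. Compound 2 `O=C1C(NC2CC2)=CC(=O)c2c1nc1n2[C@H]2OC[C@@H](O)[C@H]2OC1` reaches only a limit of this assay, > 16000 nM. Compound 3 `O=C1C(Nc2ccccc2)=CC(=O)c2c1nc1n2[C@H]2OC[C@@H](O)[C@H]2OC1` likewise reaches only a limit, > 4000 nM. The step that the two limits leave unreadable from compound 2 to compound 3 therefore stays unreadable, both of its ends sitting at a limit (the limit of > 16000 nM in this assay, at which 1 of the 3 values shown sits, (the limit of > 4000 nM in this assay, at which 1 of the 3 values shown sits)). Compound 4 `COc1ccc(NC2=CC(=O)c3nc4n(c3C2=O)[C@H]2OC[C@@H](O)[C@H]2OC4)cc1` differs from compound 1 by 4-methoxyphenyl in place of 3,4-dimethylphenyl on an amine nitrogen. No measured step in this assay bears on such a swap of aryl groups; the single step shown is the unreadable one, so no direction can be taken from the data. Compound 4 is expected to give a modest loss, a 1.9-fold higher number from compound 1 to compound 4 (0.28 log units; within the scatter), with an estimate of 4000 nM and a range of 1500 nM to 12000 nM.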

Compound 4, half-maximal inhibitory concentration: 5420 nM
Compound 4: the middle estimate sits 1.4-fold (0.13 log units) below what was measured; measured number inside the range.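

Working from the amine nitrogen, the swap to 4-methoxyphenyl gives the first readable step at this position in this assay: a 2.6-fold higher number from compound 1 to compound 4 (0.42 log units; beyond the scatter). The earlier step from cyclopropyl to phenyl cannot be read, whereas this one shows that the choice of aryl group alone moves the number beyond the scatter. Nothing measured here accounts for this step.

Still open, as far as these compounds go, is whether the step follows from the loss of the methyl groups or the entry of the methoxy group, which a 4-methylphenyl group on the same nitrogen would help separate. From the compounds shown here alone, how a 4-chlorophenyl or benzyl group would read at this nitrogen also remains open.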